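The compounds below may be only part of what the source reports. "The series", "measured", "known", "first", "only" and "open" are said of these compounds alone.

Compounds measured in a functional assay on MCF7 cells (Homo sapiens) for inhibition, read by XTT assay, with a stated time of 48 h; on this read-out lower numbers stand for stronger inhibition and higher numbers for weaker inhibition:
compound 1, `COc1ccc(C(=O)/C(=C/c2ccc(Cl)cc2Cl)CCOC(C)=O)cc1` — 83400 nM
compound 2, `COc1ccc(C(=O)/C(=C/c2ccc(Cl)cc2Cl)CC(C)OC(C)=O)cc1` — limit of > 100000 nM
compound 3, `COc1ccc(C(=O)/C(=C/c2ccc(Cl)cc2)CC(C)OC(C)=O)cc1` — limit of > 100000 nM

Compound 1 is the only one of the three with a number: in this assay compound 1 gives 83400 nM. Compound 2 sits at a limit of this assay, (the limit of > 100000 nM in this assay, at which 2 of the 3 values shown sit), so for compound 2 only that limit is known, not a number. Compound 3 likewise returns only a limit of this assay. The step of an at least 1.1-fold higher number from compound 1 to compound 2 (0.07 log units; that floor lies within the scatter) therefore has only a floor, and the step that the two limits leave unreadable from compound 2 to compound 3 cannot be read at all.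

Compound 4, `COc1ccc(C(=O)/C(=C/c2ccc(Cl)cc2Cl)CC2CCCCC2)cc1`, differs from compound 2 in one place: cyclohexyl in place of 1-acetoxyethyl on a saturated chain carbon bound to a double-bonded chain carbon. Neither measured step touches that place; the first concerns a methyl on the 1-acetoxyethyl chain and the second a chloro on the aromatic ring, and both are limited or unreadable. Within the data shown here, no measured step thus gives a direction or size for the change to cyclohexyl, and the weakness of all three compounds leaves the expected level near the limit. The estimate for compound 4 in this assay is 80000 nM, with a range from 20000 nM to 300000 nM, which means an expected step of an at least 1.2-fold lower number from compound 2 to compound 4 (0.09 log units; that floor lies within the scatter) that cannot be distinguished from no change.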

Compound 4, half-maximal inhibitory concentration: > 100000 nM
Compound 4: a limit, no number (the forecaster's own chance of this, stated with the estimate: 55%); middle value at least 1.2-fold (0.09 log units) from the limit.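

Compound 4 returns only a limit in this assay, > 100000 nM, so putting a ring of carbon only in place of the oxygen-bearing 1-acetoxyethyl chain, on a saturated chain carbon bound to a double-bonded chain carbon, yields no number, and the steps between limits cannot be read. Against compound 1, the only compound with a number, replacing acetoxymethyl with cyclohexyl gives an at least 1.1-fold higher number from compound 1 to compound 4 (0.07 log units; that floor lies within the scatter), so this change at this place shows no separation from that value. With this third limit, the change of chain leaves the series where it was: the limit of > 100000 nM in this assay, at which 3 of the 4 values shown sit.

Still open, on these data alone, is whether an amine or a carboxylic acid at this place would give a number clear of that limit. Also open, as far as these compounds go, is how far compound 2 and compound 4 actually lie apart.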